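The source may report more compounds than this note shows. Statements on the series, on what has been measured and on what is new or still open speak of the compounds shown alone.

In a functional assay on SW-620 cells (Homo sapiens) for cytotoxicity, read by MTT assay, with a stated time of 72 h (on this read-out higher numbers stand for weaker inhibition and lower numbers for stronger inhibition), compound 1 `COc1cccc(/C=C2\CCC/C(=C\c3ccc(Cl)cc3)C2=O)c1OC` gives 11100 nM, compound 2 `COc1cccc(/C=C2\CCC/C(=C\c3ccc(Br)cc3)C2=O)c1OC` gives 11100 nM and compound 3 `COc1cccc(/C=C2\CCC/C(=C\c3cccc(Cl)c3Cl)C2=O)c1OC` gives 16300 nM. Compound 3 therefore lies within the usual scatter of both others, and the three cannot be ranked. Compound 4 `COc1cccc(/C=C2\CCC/C(=C\c3cc(Cl)cc(Cl)c3)C2=O)c1OC` has 3,5-dichlorophenyl in place of 2,3-dichlorophenyl on a double-bonded chain carbon bound to a double-bonded ring carbon. Within the data shown here, no measured compound carries this exact group. The closest evidence is a 1.5-fold higher number from compound 1 to compound 3 (0.17 log units; within the scatter) and a 1.5-fold higher number from compound 2 to compound 3 (0.17 log units; within the scatter), both changes at this same place, together with no change at the digits printed from compound 1 to compound 2 (within the scatter). All three stay within the scatter, so no step beyond the scatter is expected in this assay. The expected step is a 1.3-fold lower number from compound 3 to compound 4 (0.10 log units; within the scatter). The estimate for compound 4 is 13000 nM, with an expected range from 6000 nM to 28000 nM.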

Compound 4, half-maximal inhibitory concentration: 5500 nM
Beside the measured number, compound 4's estimate is 2.4-fold (0.37 log units) above it; measured number below the stated range.
By their numbers in this assay, from the lowest: compounds 4, 1, 2 and 3 (each within the scatter of the next, the first and the last beyond it).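

Among these compounds, with the same atoms joined differently, 3,5-dichlorophenyl in place of 2,3-dichlorophenyl gives in this assay a 3.0-fold lower number from compound 3 to compound 4 (0.47 log units; beyond the scatter), the only step at this place beyond the scatter, so the arrangement of the two chlorines can matter more here than swapping one halogen. Yet a 2.0-fold lower number from compound 1 to compound 4 (0.30 log units; within the scatter) and a 2.0-fold lower number from compound 2 to compound 4 (0.30 log units; within the scatter) both stay within the scatter, so compound 4 cannot be ranked against compound 1 or compound 2. Nothing measured here explains the step. Still open, on these data alone, is how 3,5-dibromophenyl, or a phenyl carrying an amine or a carboxylic acid, would behave at this place.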